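Aryl amide variation on a shared core: acetylphenyl analogue

The source may report more compounds than this note shows. Statements on the series, on what has been measured and on what is new or still open speak of the compounds shown alone.

Compound 1 `Cc1cccc(NC(=O)CSc2nnc(-c3ccoc3C)n2Cc2ccco2)c1C` and compound 2 `Cc1occc1-c1nnc(SCC(=O)Nc2cccc(F)c2)n1Cc1ccco1` share their core with compound 3 `COc1ccc(NC(=O)CSc2nnc(-c3ccoc3C)n2Cc2ccco2)cc1` and differ from it only in the aryl group on the amide-type nitrogen. In a functional assay on CHO cells for antagonist activity at Orexin/Hypocretin receptor type 1 (Homo sapiens), read by FLIPR and calcium flux (a higher number here means a weaker inhibitor, a lower number a stronger inhibitor), compound 1 gives only a limit of > 15800 nM. Compound 2 likewise gives only a limit of > 15800 nM. Compound 3 also stands at a limit, > 15800 nM. The steps a step that the two limits leave unreadable from compound 1 to compound 2, a step that the two limits leave unreadable from compound 1 to compound 3 and a step that the two limits leave unreadable from compound 2 to compound 3 are thus not readable, since all three values sit at the limit of > 15800 nM in this assay, at which 3 of the 3 values shown sit. Compound 4 `CC(=O)c1cccc(NC(=O)CSc2nnc(-c3ccoc3C)n2Cc2ccco2)c1` differs from compound 3 by 3-acetylphenyl in place of 4-methoxyphenyl on an amide-type nitrogen. With every measured step unreadable, no direction can be drawn from them, and the expected step that the limit leaves unreadable from compound 3 to compound 4 is none beyond the scatter. Compound 4 is therefore expected at 20000 nM, range 5000 nM to 60000 nM, most likely again only a limit.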

Compound 4, inhibition constant: 3160 nM
Compound 4: middle estimate off by 6.3-fold (0.80 log units), on the high side, and the stated range ends above it.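

In this assay, among these compounds, the aryl group on the amide-type nitrogen can move the read-out, and compound 4 is the only compound here with a value that is not a limit. The 3-acetylphenyl group gives an at least 5.0-fold lower number from compound 3 to compound 4 (0.69 log units; beyond the scatter), an at least 5.0-fold lower number from compound 2 to compound 4 (0.69 log units; beyond the scatter) and an at least 5.0-fold lower number from compound 1 to compound 4 (0.69 log units; beyond the scatter). Each of these is only a bound on the step, since compound 1, compound 2 and compound 3 all stand at one limit: the limit of > 15800 nM in this assay, at which 3 of the 4 values shown sit.

From the compounds shown here alone, the true size of each step stays open. Also open, going by these compounds, is whether a carboxylic acid or a primary amide in place of the acetyl group would keep the value of compound 4.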